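Two chalcone cores, one triazole substituent swap, and an expectation

The compounds below may be only part of what the source reports. "The series", "measured", "known", "first", "only" and "open" are said of these compounds alone.

Measured so far in a functional assay on A549 cells (Homo sapiens) for antiproliferative activity, read by MTT assay; on this read-out higher numbers stand for weaker inhibition and lower numbers for stronger inhibition:
compound 1, `CC(=O)c1ccc(-n2cc(COc3ccc(/C=C/C(=O)c4cc5c(cc4O)OC(C)(C)CC5)cc3)nn2)cc1`, gives 66300 nM;
compound 2, `CCc1ccccc1-n1cc(COc2ccc(/C=C/C(=O)c3cc4c(cc3O)OC(C)(C)CC4)cc2)nn1`, gives 137000 nM;
compound 3, `CC(=O)c1ccc(-n2cc(COc3ccc(/C=C/C(=O)c4ccc5c(c4O)CCC(C)(C)O5)cc3)nn2)cc1`, gives 149000 nM.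

Compound 1 and compound 3 share the same atoms joined differently; the difference between the two cores is not broken down here. On the core of compound 1, the change 2-ethylphenyl in place of 4-acetylphenyl on an aromatic nitrogen gave a 2.1-fold higher number from compound 1 to compound 2 (0.32 log units; beyond the scatter). Compound 4, `CCc1ccccc1-n1cc(COc2ccc(/C=C/C(=O)c3ccc4c(c3O)CCC(C)(C)O4)cc2)nn1`, carries the same change on the core of compound 3, namely (2-ethylphenyl in place of 4-acetylphenyl on an aromatic nitrogen). Because the step from compound 1 to compound 2 was a 2.1-fold higher number from compound 1 to compound 2 (0.32 log units; beyond the scatter), a step of similar size is expected for compound 4, about a 1.9-fold higher number from compound 3 to compound 4 (0.27 log units; within the scatter). Compound 4 is therefore estimated at 280000 nM, with a likely range from 130000 nM to 600000 nM.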

Compound 4, half-maximal inhibitory concentration: 112000 nM
Compound 4: middle estimate off by 2.5-fold (0.40 log units), on the high side; the measured number lies below the stated range.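

Moved to the other core, the replacement of 4-acetylphenyl by 2-ethylphenyl in this assay gave a 1.3-fold lower number from compound 3 to compound 4 (0.12 log units; within the scatter), so on this core the swap has no effect that can be told from the scatter. The step therefore did not carry over in size from one core to the other: the same change on two cores in this assay, a 2.1-fold higher number (0.32 log units; beyond the scatter) from compound 1 to compound 2 and a 1.3-fold lower number (0.12 log units; within the scatter) from compound 3 to compound 4, 2.7-fold (0.44 log units) apart, beyond the scatter of two such steps. This rests on one pair per core, so it shows that the step on one core is a poor guide to the step on the other here, but it does not show why the two cores differ or how any other group would behave.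

The compounds shown leave open whether the cores also part ways with other groups on the aromatic nitrogen, such as an unsubstituted phenyl or a 4-carboxyphenyl. They also leave open whether an amine on that ring would give a step that does carry across.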